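The source may report more compounds than this note shows. Statements on the series, on what has been measured and on what is new or still open speak of the compounds shown alone.

Of the compounds shown here, two that share the same core have been measured in an assay on isolated protein for inhibition of Fatty-acid amide hydrolase 1 (Homo sapiens); on this read-out lower numbers stand for stronger inhibition and higher numbers for weaker inhibition. Compound 1 `CC(C)S(=O)(=O)N1CCC(CCCC(=O)c2ncco2)CC1` gives 140 nM. Compound 2 `COc1cccc(CN2CCC(CCCC(=O)c3ncco3)CC2)c1` gives 34 nM, the lower of the two numbers, and the gap separating compound 2 from compound 1 is wider than the usual scatter of repeated measurements. Compound 3 `O=C(CCCC1CCN(Cc2ccc(Cl)cc2)CC1)c1ncco1` has not been measured yet. It differs from compound 2 in a single place: 4-chlorophenyl in place of 3-methoxyphenyl on a saturated chain carbon bound to an amine nitrogen in a ring. For the measured compounds named here, no measured pair shows what this kind of swap does here, so the expectation rests on compound 2 and its value of 34 nM. Going by the values given here, the step from compound 2 to compound 3 is expected to be a 1.2-fold higher number from compound 2 to compound 3 (0.07 log units; within the scatter), a change that would fall within the scatter; no measured step points in either direction. On that basis compound 3 is estimated at 40 nM in this assay, with a range from 12 nM to 130 nM.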

Compound 3, half-maximal inhibitory concentration: 66 nM
Estimate against measurement, compound 3: 1.7-fold (0.22 log units) below; low and high end bracket the measured number.
By their numbers in this assay, from the lowest: compounds 2 and 3 (each within the scatter of the next); then compound 1.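

In this assay, 4-chlorophenyl in place of 3-methoxyphenyl on a saturated chain carbon bound to an amine nitrogen in a ring gives a 1.9-fold higher number from compound 2 to compound 3 (0.29 log units; within the scatter), so losing the single hydrogen-bond acceptor of the 3-methoxyphenyl group leaves no difference beyond the scatter here. At the amine nitrogen in a ring, 4-chlorobenzyl in place of isopropylsulfonyl gives a 2.1-fold lower number from compound 1 to compound 3 (0.33 log units; beyond the scatter), a modest step that stands just clear of the scatter. Nothing available explains either step. The swap from compound 2 to compound 3 alters both the substituent and its printed ring number, so 4-methoxyphenyl or 3-chlorophenyl would be needed to separate those two changes. Going by these compounds, whether the ring needs any substituent remains open too, and plain phenyl would address that.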